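Sulfur for Oxygen on the Shared Core

The compounds below may be only part of what the source reports. "The series", "measured", "known", "first", "only" and "open" are said of these compounds alone.

Of the compounds shown here, three built on one shared core have been tested in an ADME assay on MRC5 cells (Homo sapiens), read by MTT assay, with a stated time of 72 h; on this read-out higher numbers stand for weaker inhibition and lower numbers for stronger inhibition. Compound 1 `COc1ncnc2c1c(I)cn2[C@@H]1O[C@H](CO)[C@@H](O)[C@H]1O` gives 63000 nM, compound 2 `COc1ncnc2c1c(-c1ccsc1)cn2[C@@H]1O[C@H](CO)[C@@H](O)[C@H]1O` gives 75300 nM, and compound 3 `COc1ncnc2c1c(-c1ccoc1)cn2[C@@H]1O[C@H](CO)[C@@H](O)[C@H]1O` gives 29400 nM, the lowest number of the three: a 2.1-fold lower number from compound 1 to compound 3 (0.33 log units; beyond the scatter) and a 2.6-fold lower number from compound 2 to compound 3 (0.41 log units; beyond the scatter), while a 1.2-fold higher number from compound 1 to compound 2 (0.08 log units; within the scatter). Compound 4 `CSc1ncnc2c1c(-c1ccoc1)cn2[C@@H]1O[C@H](CO)[C@@H](O)[C@H]1O` differs from compound 3 elsewhere: methylsulfanyl in place of methoxy on an aromatic carbon. For the measured compounds named here, none of the measured steps touches the methoxy; each of them exchanges the iodo, thiophen-3-yl or furan-3-yl group, so they give no direct guidance for this change. The change is therefore expected to produce a step that stays within the scatter, a 1.0-fold higher number from compound 3 to compound 4 (0.01 log units; within the scatter). Compound 4 is estimated at 30000 nM, with a likely range from 10000 nM to 90000 nM.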

Compound 4, half-maximal inhibitory concentration: > 100000 nM
Compound 4 ended at the assay's limit (the forecaster's own chance of this, stated with the estimate: 10%); at least 3.3-fold (0.52 log units) between middle value and limit.
By their numbers in this assay, from the lowest: compound 3; then compounds 1 and 2 (each within the scatter of the next). At a limit, above all of these: compound 4.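

At the position that carries the methoxy, a single exchange of oxygen for sulfur does register on this read-out: methylsulfanyl in place of methoxy gives an at least 3.4-fold higher number from compound 3 to compound 4 (0.53 log units; beyond the scatter), meaning weaker inhibition. Going by these compounds, compound 4 stands at a limit of the assay, not at a true number: the limit of > 100000 nM in this assay, at which 1 of the 4 values shown sits. The full size of this step therefore stays unknown.

Still open, on these data alone, is what an amine or a longer chain such as ethylsulfanyl would do at this position. Also open, as far as these compounds go, is whether methylsulfanyl gives a similar step alongside iodo or thiophen-3-yl.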